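Replacing 2,3-dimethylphenyl with 3-chlorophenyl on a sulfonamide nitrogen

The source may hold more compounds than are shown below. What is called first, only, known or untested is meant among the compounds shown, and "the series" means these compounds.

compound 1 `CCc1cccc(NS(=O)(=O)c2ccc(N3CCNC3=O)cc2)c1` gives 82 nM
compound 2 `Cc1cccc(NS(=O)(=O)c2ccc(N3CCNC3=O)cc2)c1C` gives 110 nM

In a functional assay on M21 cells (Homo sapiens) for antiproliferative activity, read by sulforhodamine B assay, with a stated time of 48 h (on this read-out higher numbers stand for weaker inhibition and lower numbers for stronger inhibition), compound 2 cannot be told apart from compound 1. Compound 3 `O=C1NCCN1c1ccc(S(=O)(=O)Nc2cccc(Cl)c2)cc1` carries 3-chlorophenyl in place of 2,3-dimethylphenyl on a sulfonamide nitrogen. For the measured compounds named here, the only measured step at this place (a 1.3-fold higher number from compound 1 to compound 2 (0.13 log units; within the scatter)) put 2,3-dimethylphenyl in place of 3-ethylphenyl and stayed within the scatter, so for compound 3 no step beyond the scatter is expected in this assay. One step is thin evidence, so the range is kept wide. The expected step is small (a 1.1-fold lower number from compound 2 to compound 3 (0.04 log units; within the scatter)). For compound 3 the estimate is 100 nM (expected range 40 nM to 260 nM).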

Compound 3, half-maximal inhibitory concentration: 25 nM
Beside the measured number, compound 3's estimate is 4.0-fold (0.60 log units) above it; measured number below the stated range.
By their numbers in this assay, from the lowest: compound 3; then compounds 1 and 2 (each within the scatter of the next).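

In this assay, the group on a sulfonamide nitrogen now proves able to move the number beyond the scatter, which compound 1 and compound 2 alone did not show. 3-Chlorophenyl in place of 2,3-dimethylphenyl gives a 4.4-fold lower number from compound 2 to compound 3 (0.64 log units; beyond the scatter), and chloro in place of ethyl on an aromatic carbon gives a 3.3-fold lower number from compound 1 to compound 3 (0.52 log units; beyond the scatter), so both comparisons point the same way.

As far as these compounds go, whether 3-bromophenyl, 3-methoxyphenyl or 3-aminophenyl on that nitrogen would match 3-chlorophenyl stays open. No measurement at hand explains why chloro gives the lower number.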